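A few compounds are considered here, and "the series" means these few. Any claim that something is new, unique, unknown or untested is made for them only; others in the source may bear on it.

Compound 1 `CCn1nc(-c2ccnc(Nc3cccc(S(N)(=O)=O)c3)n2)c2ccccc21` gives 7260 nM in a functional assay on MCF7 cells (Homo sapiens) for antiproliferative activity, read by MTT assay, with a stated time of 72 h; a higher number here means a weaker inhibitor of growth, a lower number a stronger inhibitor of growth.
Compound 2 `CCn1nc(-c2ccnc(Nc3cccc(O)c3)n2)c2ccccc21` gives 33500 nM in this assay.

Going by the values given here, compound 1 stands with the lower of the two numbers, so it is the stronger inhibitor of growth of the pair, and the only measured step is a 4.6-fold higher number from compound 1 to compound 2 (0.66 log units; beyond the scatter), a change on the aromatic ring that carries the sulfamoyl group.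

Compound 3 `NS(=O)(=O)c1cccc(Nc2nccc(-c3nn(Cc4cccnc4)c4ccccc34)n2)c1` keeps that sulfamoyl ring unchanged. It differs from compound 1 only by pyridin-3-yl in place of methyl on a saturated chain carbon bound to an aromatic nitrogen, the change sitting on a saturated chain carbon bound to an aromatic nitrogen; cut one bond further out it reads ethyl to (pyridin-3-yl)methyl. Among the compounds with values here, the measured step does not touch this part of the shared core, so no measured step bears directly on the change, and there is nothing to support a shift in either direction beyond the scatter.

Compound 3 is therefore expected to show a 1.0-fold lower number from compound 1 to compound 3 (0.02 log units; within the scatter), giving an estimated 7000 nM with a range from 2500 nM to 20000 nM.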

Compound 3, concentration for 50% growth inhibition: 5270 nM
Estimate against measurement, compound 3: 1.3-fold (0.12 log units) above, within the range that was stated.
By their numbers in this assay, from the lowest: compounds 3 and 1 (each within the scatter of the next); then compound 2.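

The earlier step changed the aromatic ring carrying the sulfamoyl group, while this one tests the saturated chain carbon bound to an aromatic nitrogen, and it is a large change: pyridin-3-yl replaces methyl, bringing in a six-membered aromatic ring and a hydrogen-bond acceptor. Even so, this assay shows a 1.4-fold lower number from compound 1 to compound 3 (0.14 log units; within the scatter), so ethyl and (pyridin-3-yl)methyl cannot be told apart here. No other measurement accompanies this result to explain why the number holds.

On these data alone, whether it would also hold with an amine, a carboxylic acid or a longer chain at this place stays open. As far as these compounds go, it is also open whether hydroxy in place of sulfamoyl would give a similar step with (pyridin-3-yl)methyl present.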